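Alkyl chain length and maximal response at the metabotropic glutamate receptor 3

This account rests on a few compounds, and the source may have more. Where it says the series, first, only, none or still open, it means among the compounds named here.

Compound 1: `COc1cc(C(=O)O)ccc1OCCCCOc1ccc(C(=O)CC(C)C)c(O)c1C`, 73.9%
Compound 2: `COc1cc(C(=O)O)ccc1OCCCCOc1ccc(C(C)=O)c(O)c1C`, 26.3%

Of the compounds shown here, two have been measured in an assay on HEK293 cells for positive allosteric modulation of metabotropic glutamate receptor 3 (Rattus norvegicus), read by thallium flux, with a stated time of 2.5 min; on this read-out lower numbers stand for smaller maximal responses and higher numbers for larger maximal responses. Compound 2 stands lowest of the two, and its nearest neighbour is compound 1, which gives 73.9%. Within the data shown here, the only measured step, a number 47.6 percentage points lower from compound 1 to compound 2 (beyond the scatter), involves the same chain carbon that is changed here. Compound 3, `CCC(=O)c1ccc(OCCCCOc2ccc(C(=O)O)cc2OC)c(C)c1O`, differs from compound 2 in one place: methyl in place of hydrogen on a saturated chain carbon bound to a carbonyl carbon; read one bond further out, this is acetyl to propanoyl. Since adding the larger isopropyl at this position went with the large rise seen from compound 2 back to compound 1, a methyl entering at the same position is expected to move this assay upward as well, though by less, since only part of that chain is restored. The estimate for compound 3 is therefore 45%, with a range from 25% to 68%, a step of a number 18.7 percentage points higher from compound 2 to compound 3 (beyond the scatter) being expected.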

Compound 3, largest response reached (reported as percent of maximum), in percent of the reference or control that the assay uses: 25.9%
Beside the measured number, compound 3's estimate is 19.1 percentage points above it; the range from low to high includes it.
By their numbers in this assay, from the lowest: compounds 3 and 2 (each within the scatter of the next); then compound 1.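

In this assay, the propanoyl compound 3 and the acetyl compound 2 cannot be told apart, with a number 0.4 percentage points lower from compound 2 to compound 3 (within the scatter), so methyl in place of hydrogen on this saturated chain carbon bound to a carbonyl carbon is not enough to register on this read-out. Isopropyl at the same carbon does register, as a number 48 percentage points lower from compound 1 to compound 3 (beyond the scatter) shows, and the large step from compound 1 therefore stands whether hydrogen or methyl takes its place. Across these three compounds, the response at this carbon does not rise in proportion to each carbon added, and nothing given here accounts for the gap between methyl and isopropyl.

As far as these compounds go, whether ethyl or a longer straight chain at this carbon would reach the level of compound 1 stays open. So does whether a cyclopropyl or a phenyl group would do the same.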